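Swapping the thiadiazole group for a sulfonylamino group

The compounds below may be only part of what the source reports. "The series", "measured", "known", "first", "only" and "open" are said of these compounds alone.

Compound 1 `COc1ccc(CN(C(=O)Cn2cc(COc3cc(=O)oc4ccccc34)nn2)c2cc(OC)c(OC)c(OC)c2)cc1`: 5140 nM
Compound 2 `COc1ccc(CN(C(=O)Cn2cc(CSc3nncs3)nn2)c2cc(OC)c(OC)c(OC)c2)cc1`: 16500 nM

In a functional assay on PC-3 cells (Homo sapiens) for antiproliferative activity, read by MTT assay, with a stated time of 48 h (a lower number here means a stronger inhibitor, a higher number a weaker inhibitor), compound 2 gives 16500 nM, the higher of the two numbers and so the weaker result. Compound 3 `COc1ccc(CN(C(=O)Cn2cc(CNS(=O)(=O)c3ccc(C)cc3)nn2)c2cc(OC)c(OC)c(OC)c2)cc1` keeps the shared core and differs in one group: ((4-methylphenyl)sulfonyl)amino in place of (1,3,4-thiadiazol-2-yl)sulfanyl on a saturated chain carbon bound to an aromatic carbon. Going by the values given here, the only measured step changes this same place: a 3.2-fold higher number from compound 1 to compound 2 (0.51 log units; beyond the scatter). Among the compounds with values here, that modest step went between two other groups, and no measured compound carries the incoming group, so it gives only a rough size. A modest shift towards a lower number is expected in this assay, a 1.7-fold lower number from compound 2 to compound 3 (0.22 log units; within the scatter). For compound 3 the estimated value is 10000 nM, with an expected range of 3500 nM to 30000 nM.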

Compound 3, half-maximal inhibitory concentration: 12400 nM
The estimate for compound 3 lay 1.2-fold (0.09 log units) below the measured number; the measured number falls inside the stated range.
By their numbers in this assay, from the lowest: compound 1; then compounds 3 and 2 (each within the scatter of the next).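

In this assay, the step to the ((4-methylphenyl)sulfonyl)amino group is a 1.3-fold lower number from compound 2 to compound 3 (0.12 log units; within the scatter), so at this place two quite different groups, one with a hydrogen-bond donor and one without, cannot be told apart. The group of compound 1 now stands apart from both of them, with a 2.4-fold higher number from compound 1 to compound 3 (0.38 log units; beyond the scatter) adding to the earlier step. No measurement offered here explains this. Still open, from the compounds shown here alone, is how a plain amine or a carboxylic acid on this saturated chain carbon would read. Also open, going by these compounds, is whether just one of the two rings in the group of compound 1 would give a similar number.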